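Methyl in Place of Trifluoromethyl at a Weak Inhibitor

The source may report more compounds than this note shows. Statements on the series, on what has been measured and on what is new or still open speak of the compounds shown alone.

The study measures inhibition in an assay on cells for inhibition of HSP60/HSP10 (Homo sapiens), with a stated time of 60 min; on this read-out lower numbers stand for stronger inhibition and higher numbers for weaker inhibition. Compound 1 `O=S(=O)(Nc1ccc2oc(-c3ccccc3)nc2c1)c1cccc(C(F)(F)F)c1` gives in this assay only a limit, > 100000 nM. Compound 3 `O=S(=O)(Nc1ccc2oc(-c3ccccc3)nc2c1)c1ccc(F)c(C(F)(F)F)c1` gives 69000 nM in this assay, and compound 2 `CS(=O)(=O)Nc1ccc(-c2nc3cc(NS(=O)(=O)c4ccc(Cl)s4)ccc3o2)cc1` gives 43000 nM. Within the data shown here, the one measured step between compounds that differ in a single place is an at least 1.4-fold lower number from compound 1 to compound 3 (0.16 log units; that floor lies within the scatter). Compound 4 `Cc1cccc(S(=O)(=O)Nc2ccc3oc(-c4ccccc4)nc3c2)c1` has not been measured; it differs from compound 1 by methyl in place of trifluoromethyl on an aromatic carbon. Among the measured compounds shown here, no measured step involves an exchange of this kind, so nothing shows how far replacing trifluoromethyl by methyl moves the number; the measured step touches compound 4 only in that it starts from the same limit (the limit of > 100000 nM in this assay, at which 1 of the 3 values shown sits), and even that step did not leave the scatter. Compound 4 is therefore expected to stay near the limit, with a number no higher from compound 1 to compound 4 (the limit leaves the size open) expected to lie within the scatter. The estimate for compound 4 is 100000 nM, between 30000 nM and 300000 nM.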

Compound 4, half-maximal inhibitory concentration: > 100000 nM
Compound 4: no number, only a limit (the forecaster's own chance of this, stated with the estimate: 55%); the middle value lies on the limit itself.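

In this assay compound 4 gives > 100000 nM as a limit and not a number. Among these compounds, compound 1 also stands only at a limit, so no step between compound 1 and compound 4 can be read: the limit of > 100000 nM in this assay, at which 2 of the 4 values shown sit. The compounds shown leave open how far methyl in place of trifluoromethyl moves the number.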